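A few compounds are considered here, and "the series" means these few. Any claim that something is new, unique, unknown or untested is made for them only; others in the source may bear on it.

Measured compounds in a functional assay on HL-60 cells (Homo sapiens) for cytotoxicity, read by MTT assay, with a stated time of 24 h; a higher number here means a weaker inhibitor, a lower number a stronger inhibitor:

compound 1, `CC(C)(C)OC(=O)N1CCCN(CCCCCOc2c(Br)cc(Br)cc2Oc2ccc(Br)cc2Br)CC1`: in this assay compound 1 gives 44.8 ug/mL
compound 2, `Brc1ccc(Oc2cc(Br)cc(Br)c2OCCCCCN2CCN(C/C=C/c3ccccc3)CC2)c(Br)c1`: in this assay compound 2 gives 47.2 ug/mL
compound 3, `C#CCOc1c(Br)cc(Br)cc1Oc1ccc(Br)cc1Br`: in this assay compound 3 gives 29.7 ug/mL

All three numbers sit within the usual scatter of one another, so no ranking among compound 1, compound 2 and compound 3 can be read from them; compound 3 gives the lowest figure, but its gap to compound 1 and to compound 2 is inside the scatter. No pair of these compounds differs in only one place, so no single-point step is available for calibration.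

Compound 4, `CC(C)(C)C(=O)C(C#N)Oc1c(Br)cc(Br)cc1Oc1ccc(Br)cc1Br`, differs from compound 3 at one place:

cyano((tert-butyl)carbonyl)methyl in place of propargyl on an oxygen on an aromatic ring

The shared core is kept. Without any measured step of comparable kind, the expectation for this assay is a change of no more than the scatter, in either direction, and the estimated step of a 1.0-fold higher number from compound 3 to compound 4 (0.00 log units; within the scatter) is therefore taken as essentially flat. Compound 4 is expected to give about 30 ug/mL, within a range of 12 ug/mL to 75 ug/mL.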

Compound 4, half-maximal inhibitory concentration: 29.2 ug/mL
Estimate against measurement, compound 4: 1.0-fold (0.01 log units) above; low and high end bracket the measured number.
By their numbers in this assay, from the lowest: compounds 4, 3, 1 and 2 (each within the scatter of the next).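

In this assay, for the compounds shown here, the exchange of propargyl for cyano((tert-butyl)carbonyl)methyl on an oxygen on an aromatic ring gives a 1.0-fold lower number from compound 3 to compound 4 (0.01 log units; within the scatter) and is the only single-place step available. At this position, a group of 9 heavy atoms with 2 hydrogen-bond acceptors thus replaces one of 3 heavy atoms with 0 hydrogen-bond acceptors, and the reading stays within the scatter. No supporting data bear on the reason for this flat step.

One step cannot show whether the same flat result holds for other groups on this oxygen, such as a carboxylic acid or a primary amine at the end of a short chain. Also open, as far as these compounds go, is how the shared core reads with a plain hydroxyl on that oxygen and no chain at all.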